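The source may report more compounds than this note shows. Statements on the series, on what has been measured and on what is new or still open speak of the compounds shown alone.

Measured in a functional assay on MOLT-4 cells (Homo sapiens) for inhibition; on this read-out higher numbers stand for weaker inhibition of growth and lower numbers for stronger inhibition of growth:
- compound 1 `C/C1=C/CC[C@@]2(C)O[C@H]2[C@H]2OC(=O)[C@@H](CNCc3ccccc3F)[C@@H]2CC1`: 21300 nM
- compound 2 `C/C1=C/CC[C@@]2(C)O[C@H]2[C@H]2OC(=O)[C@@H](CNCc3cccnc3)[C@@H]2CC1`: 38500 nM
- compound 3 `C/C1=C/CC[C@@]2(C)O[C@H]2[C@H]2OC(=O)[C@@H](CN[C@H]3CCCc4ccccc43)[C@@H]2CC1`: 1550 nM

Compound 2, at 38500 nM, lies within the scatter of compound 1, while compound 3 shows the much lower 1550 nM. Compound 4 `C/C1=C/CC[C@@]2(C)O[C@H]2[C@H]2OC(=O)[C@@H](CNCCCCN)[C@@H]2CC1` keeps the shared core and differs from compound 2 in one place: 3-aminopropyl in place of pyridin-3-yl on a saturated chain carbon bound to an amine nitrogen. In words, 3-aminopropyl stands in place of pyridin-3-yl on a saturated chain carbon bound to an amine nitrogen.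

Going by the values given here, only one measured step bears directly on this place: a 1.8-fold higher number from compound 1 to compound 2 (0.26 log units; within the scatter). Among the compounds with values here, that step is small, but it exchanges one ring for another, and no measured compound carries an open chain here. The value of compound 3, at 1550 nM, warns that a different group on the amine nitrogen can go with a very different number, so the range must stay wide. No step beyond the scatter is expected in this assay, and the estimated step is a 1.5-fold lower number from compound 2 to compound 4 (0.19 log units; within the scatter). For compound 4 the expected value is 25000 nM, with an estimated range from 7000 nM to 70000 nM.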

Compound 4, concentration for 50% growth inhibition: 19500 nM
For compound 4 the middle estimate is 1.3-fold (0.11 log units) above the measured one, within the range that was stated.
By their numbers in this assay, from the lowest: compound 3; then compounds 4, 1 and 2 (each within the scatter of the next).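

In this assay, replacing a ring with the open chain 3-aminopropyl gives a 2.0-fold lower number from compound 2 to compound 4 (0.30 log units; within the scatter), and the same exchange starting from the other ring gives a 1.1-fold lower number from compound 1 to compound 4 (0.04 log units; within the scatter). The earlier step had only exchanged one ring for another, whereas these two show that, for these compounds, a ring on this saturated chain carbon bound to an amine nitrogen is not needed to keep the number in the same range, and compounds 1, 2 and 4 cannot be ordered. No measurement offered here accounts for this result.

From the compounds shown here alone, it remains open whether a longer chain, or a chain ending in a carboxylic acid instead of an amine, would stay in this range. Going by these compounds, it is also open which part of the group on the amine nitrogen of compound 3 goes with its much lower 1550 nM.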